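Notes on the branched chain at the aromatic nitrogen

The source may hold more compounds than are shown below. What is called first, only, known or untested is meant among the compounds shown, and "the series" means these compounds.

Going by the values given here, compound 1 `CCC(CC)Cn1c(Cc2cc(OC)c(OC)c(OC)c2)nc2c(N)ncnc21` stands at the higher of the two numbers so far in a functional assay on MCF7 cells (Homo sapiens) for antiproliferative activity; a higher number here means a weaker inhibitor, a lower number a stronger inhibitor: compound 1 gives 158000 nM, and compound 2 `CCCCn1c(Cc2cc(OC)c(OC)c(OC)c2)nc2c(N)nc(F)nc21` gives 24000 nM. Compound 2 differs from compound 1 in more than one place, so the two values show only that they lie apart, beyond the scatter, and not what any single change did.

Compound 3 `COc1cc(Cc2nc3c(N)ncnc3n2CC2(C)CC2)cc(OC)c1OC` is not yet measured. Against compound 1 the change is 1-methylcyclopropyl in place of pentan-3-yl on a saturated chain carbon bound to an aromatic nitrogen. The group that leaves has no ring; the group that enters carries one three-membered non-aromatic ring of carbon only.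

Among the compounds with values here, no measured pair isolates a change of this kind. The step expected from compound 1 to compound 3 is therefore small, with a slight lean toward a lower number, and is estimated as a 1.6-fold lower number from compound 1 to compound 3 (0.20 log units; within the scatter). Compound 3 is expected to give about 100000 nM in this assay, with a range from 30000 nM to 400000 nM.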

Compound 3, half-maximal inhibitory concentration: 112000 nM
Compound 3: middle estimate off by 1.1-fold (0.05 log units), on the low side, within the range that was stated.
By their numbers in this assay, from the lowest: compound 2; then compounds 3 and 1 (each within the scatter of the next).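

In this assay, going by these compounds alone, the first comparison at this position that isolates a single change gives a 1.4-fold lower number from compound 1 to compound 3 (0.15 log units; within the scatter), which is within the scatter. At this place on the shared core, on a saturated chain carbon bound to an aromatic nitrogen, the open branched pentan-3-yl and the 1-methylcyclopropyl carrying a three-membered non-aromatic ring of carbon only cannot be told apart. No measurement is available to explain this result.

Compound 2 differs from both compound 1 and compound 3 in more than one place, so those steps cannot be read. From the compounds shown here alone, whether an amine, a carboxylic acid or a longer chain at this place would shift the number beyond the scatter remains open.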